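Ethoxy analogue of compound 1: expected distribution volume

A few compounds are considered here, and "the series" means these few. Any claim that something is new, unique, unknown or untested is made for them only; others in the source may bear on it.

Among the compounds with values here, compound 1 `O=C(O)Cn1nc(Cc2nc3cc(Cl)c(OCC(F)F)cc3[nH]2)c2ccccc2c1=O` gives 1.2 L/kg in an ADME assay on the whole organism (Mus musculus, strain CD1) for pharmacokinetics, read by LC-MS, with a stated time of 24 h, at a dose of 1 mg/kg by the intravenous route (a higher number here means that more of the compound sits outside the plasma, a lower number that more of the compound stays in the plasma), the higher of the two numbers measured so far; compound 2 `O=C(O)Cn1nc(Cc2cn3cc(OCC4CC4)c(Cl)cc3n2)c2ccccc2c1=O` gives 0.28 L/kg in this assay, a gap beyond the scatter. Compound 3 `CCOc1cc2[nH]c(Cc3nn(CC(=O)O)c(=O)c4ccccc34)nc2cc1Cl` is compound 1 with methyl in place of difluoromethyl on a saturated chain carbon bound to an oxygen on an aromatic ring. Within the data shown here, no step between measured compounds isolates this change, and compounds 1 and 2 differ at more than one place. Given the small counted change, no step beyond the scatter is expected in either direction. Compound 3 is expected to give 1 L/kg in this assay, with a range of 0.5 L/kg to 2 L/kg. The step of a 1.2-fold lower number from compound 1 to compound 3 (0.08 log units; within the scatter) is expected to stay within the scatter.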

Compound 3, volume of distribution at steady state: 0.5 L/kg
Beside the measured number, compound 3's estimate is 2.0-fold (0.30 log units) above it, and the stated range covers the measured number.
By their numbers in this assay, from the lowest: compounds 2 and 3 (each within the scatter of the next); then compound 1.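

In this assay, within the data shown here, going from 2,2-difluoroethoxy to ethoxy gives the only single-place step (a 2.4-fold lower number from compound 1 to compound 3 (0.38 log units; beyond the scatter)). This position on the shared core therefore registers in the read-out: replacing difluoromethyl with methyl on the saturated chain carbon gives a modest step beyond the scatter. No available measurement bears on the reason for this step.

Still open, on these data alone, is whether a longer chain, a trifluoroethyl group or an amine at this place would shift the read-out further. As far as these compounds go, whether the step carries over to the core of compound 2 also remains open.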